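The compounds below may be only part of what the source reports. "The series", "measured", "known", "first", "only" and "open" are said of these compounds alone.

In a functional assay on HCT-116 cells (Homo sapiens) for cytotoxicity, read by MTT assay, with a stated time of 48 h (a lower number here means a stronger inhibitor of growth, a higher number a weaker inhibitor of growth), the three measured compounds sit close together. Compound 1 `Clc1cc2ncn(C3CCCC3)c2cc1Cl` gives 37000 nM, compound 2 `CCc1nc2cc(Cl)c(Cl)cc2n1C1CCCC1` gives 38000 nM, and compound 3 `FC(F)(F)c1nc2cc(Cl)c(Cl)cc2n1C1CCCC1` gives 22000 nM, which places compound 3 within the scatter of both others.

The next compound is compound 4 `CC(C)c1nc2cc(Cl)c(Cl)cc2n1C1CCCC1`, with isopropyl in place of trifluoromethyl on an aromatic carbon, next to the ring atom that bears a cyclopentyl group: isopropyl in place of trifluoromethyl on an aromatic carbon.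

Three measured steps change the group at this carbon. The two that replace hydrogen are a 1.0-fold higher number from compound 1 to compound 2 (0.01 log units; within the scatter) and a 1.7-fold lower number from compound 1 to compound 3 (0.23 log units; within the scatter). Going by the values given here, the closest precedent, trifluoromethyl in place of ethyl, is a 1.7-fold lower number from compound 2 to compound 3 (0.24 log units; within the scatter). All three lie within the scatter, so no step beyond the scatter is expected in this assay.

With ethyl at that carbon, compound 2 gives 38000 nM, and this value draws the expectation slightly towards it. The estimated change is a 1.5-fold higher number from compound 3 to compound 4 (0.16 log units; within the scatter), which is not expected to exceed the scatter. The expected value for compound 4 is 32000 nM. The estimated range for compound 4 runs from 17000 nM to 60000 nM.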

Compound 4, concentration for 50% growth inhibition: 9000 nM
Compound 4: middle estimate off by 3.6-fold (0.55 log units), on the high side, outside the stated range (below it).
By their numbers in this assay, from the lowest: compound 4; then compounds 3, 1 and 2 (each within the scatter of the next).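

In this assay, going by these compounds alone, isopropyl is the first group at this carbon to give a change beyond the scatter, with a 2.4-fold lower number from compound 3 to compound 4 (0.39 log units; beyond the scatter) and a 4.1-fold lower number from compound 1 to compound 4 (0.61 log units; beyond the scatter) and also a 4.2-fold lower number from compound 2 to compound 4 (0.63 log units; beyond the scatter) in the same direction. The last of these steps is only methyl in place of hydrogen on the saturated chain carbon bound to the aromatic carbon, so the branched isopropyl separates from ethyl even though ethyl stays within the scatter of hydrogen. Nothing available on these compounds accounts for the difference.

The compounds shown leave open whether tert-butyl, a cyclopropyl ring or a longer chain at this carbon would extend the step or lose it. They also leave open how an amine or a carboxylic acid would read at the same place.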